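A few compounds are considered here, and "the series" means these few. Any claim that something is new, unique, unknown or untested is made for them only; others in the source may bear on it.

Working notes on the series. Three compounds carry the same core with a different aryl substituent pattern. Compound 1 `COC(=O)C1=C(C)N=C(C)/C(=C(/O)OC)C1c1c(F)cccc1Cl` and compound 2 `COC(=O)C1=C(C)N=C(C)/C(=C(\O)OC)C1c1c(Cl)cccc1Cl` differ only in one halogen on the aryl ring; in a functional assay (muscle tissue) with Cavia porcellus as the target (a higher number here means that more compound is needed for the effect, a lower number that less compound is needed), compound 1 gives 7.59 nM and compound 2 gives 1.91 nM. Compound 3 `COC(=O)C1=C(C)N=C(C)/C(=C(\O)OC)C1c1cccc(OC(=O)c2ccccc2)c1` carries a benzoyloxy instead and stands apart: in this assay compound 3 gives 6310 nM, the highest of the three numbers, far beyond the scatter from both compound 1 and compound 2, so compound 3 is the weakest of the set.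

The next compound, compound 4 `COC(=O)C1=C(C)N=C(C)/C(=C(\O)OC)C1c1cccc([N+](=O)[O-])c1`, keeps the core and the aryl ring of compound 3 and changes one group: nitro in place of benzoyloxy on an aromatic carbon. The group that leaves is much the larger one, the group that enters is small, and the position on the aromatic ring, meta to a large group, is kept.

Within the data shown here, no measured pair in the set isolates this exchange, so the expectation rests on where compound 3 stands relative to compound 1 and compound 2. The step from compound 3 is expected to be downward and clearly beyond the scatter, with a 210-fold lower number from compound 3 to compound 4 (2.32 log units; beyond the scatter). For compound 4 in this assay the estimate is 30 nM, in the range 4 nM to 250 nM.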

Compound 4, half-maximal effective concentration: 3.98 nM
For compound 4 the middle estimate is 7.5-fold (0.88 log units) above the measured one; measured number below the stated range.
By their numbers in this assay, from the lowest: compound 2; then compounds 4 and 1 (each within the scatter of the next); then compound 3.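

In this assay, among these compounds, nitro in place of benzoyloxy on an aromatic carbon gives a 1600-fold lower number from compound 3 to compound 4 (3.20 log units; beyond the scatter) and is the first change that can be read directly at this place. The step is large and beyond the scatter, so the high number of compound 3 is tied to the benzoyloxy group and not to the shared core, which compound 4 keeps while giving 3.98 nM in this assay. The exchange replaces a group of 9 heavy atoms holding an aromatic ring with a group of 3 heavy atoms and no ring, but no measurement available here accounts for the drop in the number.

One pair cannot separate the loss of the benzoyloxy group from the arrival of nitro, and a simple amine, a methoxy group or a carboxylic acid on the same aromatic carbon would be needed to tell these apart. From the compounds shown here alone, whether nitro and benzoyloxy would differ as widely on another carbon of the aromatic ring also remains open.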